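From 3-nitrophenyl to 2-chlorophenyl on a shared core

The source may report more compounds than this note shows. Statements on the series, on what has been measured and on what is new or still open speak of the compounds shown alone.

Measured in a functional assay on A549 cells (Homo sapiens) for cytotoxicity, read by MTT assay, with a stated time of 24 h; a higher number here means a weaker inhibitor, a lower number a stronger inhibitor:
Compound 1 `C/C(=N\NC(=O)/C(C#N)=C/c1ccc(O)cc1)c1c(O)c2ccc(O)cc2oc1=O`: 6230 nM
Compound 2 `COc1ccc(/C=C(\C#N)C(=O)N/N=C(\C)c2c(O)c3ccc(O)cc3oc2=O)cc1`: 8150 nM
Compound 3 `C/C(=N\NC(=O)/C(C#N)=C/c1cccc([N+](=O)[O-])c1)c1c(O)c2ccc(O)cc2oc1=O`: 21900 nM

Compound 3 has the highest number of the three and is the weakest of them. Compound 4 `C/C(=N\NC(=O)/C(C#N)=C/c1ccccc1Cl)c1c(O)c2ccc(O)cc2oc1=O` carries 2-chlorophenyl in place of 3-nitrophenyl on a double-bonded chain carbon bound to a double-bonded chain carbon. Two measured changes at this place bear on it, both modest: a 3.5-fold higher number from compound 1 to compound 3 (0.55 log units; beyond the scatter) and a 2.7-fold higher number from compound 2 to compound 3 (0.43 log units; beyond the scatter). The third, a 1.3-fold higher number from compound 1 to compound 2 (0.12 log units; within the scatter), lies within the scatter. For the measured compounds named here, no chlorinated compound has been measured, so a modest fall in this assay is expected, with little certainty. The expected size is a 1.8-fold lower number from compound 3 to compound 4 (0.26 log units; within the scatter). For compound 4 the estimate is 12000 nM, with an expected range of 5000 nM to 28000 nM.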

Compound 4, half-maximal inhibitory concentration: 14200 nM
Estimate against measurement, compound 4: 1.2-fold (0.07 log units) below; measured number inside the range.
By their numbers in this assay, from the lowest: compounds 1, 2, 4 and 3 (each within the scatter of the next, the first and the last beyond it).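

In this assay, replacing 3-nitrophenyl with 2-chlorophenyl gives a 1.5-fold lower number from compound 3 to compound 4 (0.19 log units; within the scatter), and replacing 4-methoxyphenyl with it gives a 1.7-fold higher number from compound 2 to compound 4 (0.24 log units; within the scatter), so a chlorinated ring at this place cannot be told apart from either group. Only 4-hydroxyphenyl separates from it, with a 2.3-fold higher number from compound 1 to compound 4 (0.36 log units; beyond the scatter). No supporting measurement accounts for these differences. Going by these compounds, what an amine or a carboxylic acid on this phenyl ring would do in this assay remains open.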